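Ring expansion at the thiocarbonyl amine of compound 2

A few compounds are considered here, and "the series" means these few. Any claim that something is new, unique, unknown or untested is made for them only; others in the source may bear on it.

The shared core carries an amide of a trimethoxyphenyl aniline with a methoxybenzyl group, linked through a thioacetyl bridge to a dithiocarbamate whose amine part varies. Compound 1 `CCN1CCN(C(=S)SCC(=O)N(Cc2ccc(OC)cc2)c2cc(OC)c(OC)c(OC)c2)CC1` bears a 4-ethylpiperazin-1-yl group there, and in a functional assay on KYSE-450 cells (Homo sapiens) for inhibition, read by CCK-8 assay, with a stated time of 48 h (on this read-out lower numbers stand for stronger inhibition and higher numbers for weaker inhibition), compound 1 gives 3070 nM. Compound 2 `COc1ccc(CN(C(=O)CSC(=S)N2CCc3ccccc32)c2cc(OC)c(OC)c(OC)c2)cc1` instead carries a 2,3-dihydro-1H-indol-1-yl group, and in this assay compound 2 gives 6940 nM, which is the highest of the two numbers recorded; the step of a 2.3-fold higher number from compound 1 to compound 2 (0.35 log units; beyond the scatter) shows that exchanging the amine at this position shifts the number modestly.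

Compound 3 `COc1ccc(CN(C(=O)CSC(=S)N2CCCc3cc(OC)ccc32)c2cc(OC)c(OC)c(OC)c2)cc1` keeps everything else and differs from compound 2 only in this amine: 6-methoxy-1,2,3,4-tetrahydroquinolin-1-yl in place of 2,3-dihydro-1H-indol-1-yl on a thiocarbonyl carbon. Among the measured compounds shown here, no measured step covers this exact exchange. For the measured compounds named here, the only step that bears on it, a 2.3-fold higher number from compound 1 to compound 2 (0.35 log units; beyond the scatter), shows that changing the amine on the thiocarbonyl carbon moved the number by a modest amount, without showing which way a larger, methoxy-bearing ring system would move it. A step within the scatter, or a modest one in either direction, is therefore expected for a 1.2-fold lower number from compound 2 to compound 3 (0.06 log units; within the scatter). Compound 3 is estimated to give 6000 nM, with a range from 2500 nM to 15000 nM.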

Compound 3, half-maximal inhibitory concentration: 5530 nM
Compound 3: middle estimate off by 1.1-fold (0.04 log units), on the high side; the range from low to high includes it.
By their numbers in this assay, from the lowest: compounds 1, 3 and 2 (each within the scatter of the next, the first and the last beyond it).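

In this assay, replacing the 2,3-dihydro-1H-indol-1-yl group with the 6-methoxy-1,2,3,4-tetrahydroquinolin-1-yl group on the thiocarbonyl carbon gives a 1.3-fold lower number from compound 2 to compound 3 (0.10 log units; within the scatter) and so does not separate the two amines, even though the saturated ring grows from five-membered to six-membered and a methoxy group is added. Replacing the 4-ethylpiperazin-1-yl group with the same 6-methoxy-1,2,3,4-tetrahydroquinolin-1-yl group gives a 1.8-fold higher number from compound 1 to compound 3 (0.26 log units; within the scatter) and does not separate those two amines either. Compound 3 therefore lies within the scatter of both earlier compounds, although those two lie beyond the scatter of each other, so the three amines shown do not fall into two clearly separate groups. No accompanying measurement offers an explanation for these numbers.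

Compound 3 carries the larger ring and the methoxy group together, and the plain 1,2,3,4-tetrahydroquinolin-1-yl group would be needed to tell their contributions apart. On these data alone, it also remains open whether a morpholin-4-yl group or an open-chain diethylamino group on the thiocarbonyl carbon would give a number close to these three.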